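Trimming an Ethoxy Group to Methoxy on a Shared Core

A few compounds are considered here, and "the series" means these few. Any claim that something is new, unique, unknown or untested is made for them only; others in the source may bear on it.

Of the compounds shown here, two have numbers so far. Compound 1 `CC[C@@H](Nc1c(C#N)c(-c2ccc(-c3ccccc3F)cc2)nc2cnccc12)C(N)=O` gives 140 nm/s in an ADME assay on Caco-2 cells (Homo sapiens) for permeability, read by LC-MS, in the apical to basolateral direction, with a stated time of 2 h, tested at 2 uM; a lower number here means that the compound crosses the layer more slowly, a higher number that the compound crosses the layer faster. Compound 2 `CCOc1ccccc1-c1ccc(-c2nc3cnccc3c(N[C@H](CC)C(N)=O)c2C#N)cc1` carries ethoxy in place of fluoro on an aromatic carbon, and in this assay compound 2 gives 151 nm/s. Of the two numbers, compound 2 stands nearest compound 1, and the step of a 1.1-fold higher number from compound 1 to compound 2 (0.03 log units; within the scatter) is within the scatter, so the two cannot be told apart here. Compound 3 `CC[C@@H](Nc1c(C#N)c(-c2ccc(-c3ccccc3OC)cc2)nc2cnccc12)C(N)=O` is not yet measured. It differs from compound 2 by hydrogen in place of methyl on a saturated chain carbon bound to an oxygen on an aromatic ring; read one bond further out, ethoxy becomes methoxy. Within the data shown here, the only measured step touching this part of the structure is a 1.1-fold higher number from compound 1 to compound 2 (0.03 log units; within the scatter), which swapped fluoro for the whole ethoxy and moved nothing beyond the scatter. A smaller trim, ethyl to methyl, is therefore expected to leave the number where it is. The expected step is a 1.0-fold lower number from compound 2 to compound 3 (0.02 log units; within the scatter). Compound 3 is estimated at 145 nm/s, between 90 nm/s and 230 nm/s.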

Compound 3, apparent permeability: 160 nm/s
For compound 3 the middle estimate is 1.1-fold (0.04 log units) below the measured one, within the range that was stated.
By their numbers in this assay, from the lowest: compounds 1, 2 and 3 (each within the scatter of the next).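

Cutting ethoxy back to methoxy gives a 1.1-fold higher number from compound 2 to compound 3 (0.03 log units; within the scatter) in this assay, and the comparison of methoxy with fluoro gives a 1.1-fold higher number from compound 1 to compound 3 (0.06 log units; within the scatter), so neither step can be told apart from repeat measurement. Compound 3 adds a third group at this place on the aromatic ring, and fluoro, ethoxy and methoxy now all give numbers that lie within the scatter of one another, which one step alone could not show. Nothing at hand offers a reason for this sameness.

As far as these compounds go, these three groups cover only a narrow choice at this place, so it remains open whether an amine, a carboxylic acid or a longer chain such as butoxy would move the number beyond the scatter. All three compounds also share the rest of the structure, which leaves open whether the same holds on a different core.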